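This account rests on a few compounds, and the source may have more. Where it says the series, first, only, none or still open, it means among the compounds named here.

Working notes on the series in a functional assay on DU-145 cells (Homo sapiens) for inhibition, read by trypan blue exclusion, with a stated time of 96 h; a higher number here means a weaker inhibitor of growth, a lower number a stronger inhibitor of growth. Compound 1 (`Cc1ccc(CS/C(=C/c2ccc(O)cc2)C(=O)c2ccc(Cl)cc2)cc1`) gives 10000 nM, compound 2 (`O=C(O)c1ccc(C(=O)/C(=C\c2ccc(O)c([N+](=O)[O-])c2)SCc2ccc(Br)cc2)cc1`) gives 50000 nM and compound 3 (`COc1cc(/C=C(/SCc2ccc(Br)cc2)C(=O)c2ccc(C(=O)O)cc2)ccc1F`) gives 1000 nM, which leaves compound 2 with the highest number of the three.

The change under review leads to compound 4 (`O=C(/C(=C\c1ccc(O)c([N+](=O)[O-])c1)SCc1ccc(Br)cc1)c1ccc(Cl)cc1Cl`): 2,4-dichlorophenyl in place of 4-carboxyphenyl on a carbonyl carbon. Within the data shown here, no measured step covers this place. Among the measured compounds shown here, the only single-place step, a 50-fold lower number from compound 2 to compound 3 (1.70 log units; beyond the scatter), is large, but it concerns the group on a double-bonded chain carbon, so it shows only that numbers can move far from compound 2. The closest indication is compound 1, which has a chlorine-bearing ring on the carbonyl carbon and gives 10000 nM, although it also differs from compound 2 elsewhere. A moderate move to a lower number is therefore expected, smaller than the measured step. The estimated step is a 5.0-fold lower number from compound 2 to compound 4 (0.70 log units; beyond the scatter). The estimate for compound 4 is 10000 nM, with an expected range of 2500 nM to 40000 nM.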

Compound 4, concentration for 50% growth inhibition: 10000 nM
Estimate against measurement, compound 4: no gap at the digits printed; the range from low to high includes it.
By their numbers in this assay, from the lowest: compound 3; then compounds 1 and 4 (each within the scatter of the next); then compound 2.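

In this assay the carbonyl carbon proves to be a place that responds to change: a 5.0-fold lower number from compound 2 to compound 4 (0.70 log units; beyond the scatter) is modest but beyond the scatter, with 2,4-dichlorophenyl in place of 4-carboxyphenyl. With the 4-hydroxy-3-nitrophenyl group held constant, the carboxylic acid is therefore not needed for the number to fall, and the entering group, with 0 hydrogen-bond donors and 0 hydrogen-bond acceptors, still gives the lower number. No measured evidence accounts for this shift.

Among these compounds, the single exchange leaves the contributions of the lost carboxylic acid and of the two chlorines unseparated, so it remains open whether a 4-chlorophenyl group, a plain phenyl group, a methyl ester or an amide would match compound 2 or compound 4. As far as these compounds go, it is also open whether the same exchange would move the number in the same direction with the 4-fluoro-3-methoxyphenyl group of compound 3 in place.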